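The source may report more compounds than this note shows. Statements on the series, on what has been measured and on what is new or still open speak of the compounds shown alone.

Working notes on the series. In a functional assay on HCT-116 cells (Homo sapiens) for antiproliferative activity, with a stated time of 72 h (on this read-out higher numbers stand for weaker inhibition and lower numbers for stronger inhibition), compound 1 `CC(=O)Oc1ccccc1/C=C/c1nc2ccccc2c(=O)[nH]1` gives 17200 nM and compound 2 `CC(=O)Oc1cccc(/C=C/c2nc3ccccc3c(=O)[nH]2)c1` gives 9290 nM. For the measured compounds named here, these two values lie within the scatter of each other, so compound 1 stands level with its only measured neighbour. Compound 3 `CC(=O)Oc1ccc(/C=C/c2nc3ccccc3c(=O)[nH]2)c(OC(C)=O)c1` keeps the acetoxy group of compound 1 and adds a second one: acetoxy in place of hydrogen on an aromatic carbon. The new acetoxy sits meta to the existing acetoxy group and para to a large group. Going by the values given here, no measured step shows what such a change does. The expectation rests only on compound 1 at 17200 nM and compound 2 at 9290 nM, which give no sign of a large shift. In this assay, a small downward step is expected, possibly none beyond the scatter. The estimated change is a 1.6-fold lower number from compound 1 to compound 3 (0.19 log units; within the scatter). For compound 3 the expected value is 11000 nM, with an estimated range of 3500 nM to 32000 nM.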

Compound 3, half-maximal inhibitory concentration: 23000 nM
Compound 3: middle estimate off by 2.1-fold (0.32 log units), on the low side; low and high end bracket the measured number.
By their numbers in this assay, from the lowest: compounds 2, 1 and 3 (each within the scatter of the next, the first and the last beyond it).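

In this assay, for the compounds shown here, acetoxy in place of hydrogen on an aromatic carbon, meta to the acetoxy group of compound 1 and para to a large group, gives a 1.3-fold higher number from compound 1 to compound 3 (0.13 log units; within the scatter) as the first measured step at this position. Going by these compounds alone, the added acetoxy, with its 4 heavy atoms and 2 hydrogen-bond acceptors, therefore leaves the number of compound 3 level with that of compound 1, and the series so far holds no step beyond the scatter. Nothing measured here accounts for the size of this step.

Open, going by these compounds, is whether an amine, a carboxylic acid or a longer chain on this same aromatic carbon would move the number beyond the scatter. Also open, on these data alone, is what a second acetoxy would do on compound 2.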